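Chloro in Place of Methoxy: From Compound 2 to Compound 4

The compounds below may be only part of what the source reports. "The series", "measured", "known", "first", "only" and "open" are said of these compounds alone.

Of the compounds shown here, three that share a core have been tested in an ADME assay on microsomes from liver (Mus musculus) for metabolic stability, read by LC-MS, using NADPH, with a stated time of 10 min, tested at 0.5 uM; a higher number here means that more of the compound is left, a lower number that less of the compound is left. Compound 1 `Cc1cc(-c2cc(C)c(OC[C@@](C)(N)CC(C)C)cn2)ccn1` gives 72%, and compound 3 `CC(=O)Nc1cc(-c2ccc(OC[C@@H](N)CC(C)C)c(Cl)c2)ccn1` gives 86%. Compound 2 `COC(=O)Nc1cc(-c2cnc(OC[C@@](C)(N)CC(C)C)c(OC)c2)ccn1` gives 59%, the lowest of the three values; its gap to compound 1 and its larger gap to compound 3 both lie beyond the usual scatter of this assay.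

Compound 4 `COC(=O)Nc1cc(-c2cnc(OC[C@@](C)(N)CC(C)C)c(Cl)c2)ccn1` has not yet been measured. It differs from compound 2 in one place: chloro in place of methoxy on an aromatic carbon. Within the data shown here, no pair of measured compounds differs in exactly this way, so the step cannot be read off directly.

A modest rise in this assay is expected from compound 2 to compound 4, a number 9 percentage points higher from compound 2 to compound 4 (within the scatter), because compound 3 also carries a chloro and gives 86%, although compound 3 differs from compound 4 in further places as well. Compound 4 is therefore estimated to give 68%, within a range from 52% to 82%.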

Compound 4, percent of the compound remaining: 65%
Compound 4: the middle estimate sits 3 percentage points above what was measured, within the range that was stated.
By their numbers in this assay, from the lowest: compounds 2, 4 and 1 (each within the scatter of the next, the first and the last beyond it); then compound 3.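

Among these compounds, this is the first reading of a single change at this position, on an aromatic carbon ortho to a (2-amino-2,4-dimethylpentyl)oxy group: in this assay, chloro in place of methoxy gives a number 6 percentage points higher from compound 2 to compound 4 (within the scatter) on the shared core. The swap exchanges a group of 2 heavy atoms and 1 hydrogen-bond acceptor for a single chlorine with none, yet the two compounds cannot be told apart in this read-out. No supporting measurement bears on why this swap leaves the reading within the scatter.

From the compounds shown here alone, whether fluoro, a nitrile or a longer ether chain such as ethoxy on this carbon would move the reading beyond the scatter remains open. So does whether chloro in place of methoxy would give a similar step with a different group on the rest of the molecule.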